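Methoxy in place of hydrogen on the phenyl ring

This account rests on a few compounds, and the source may have more. Where it says the series, first, only, none or still open, it means among the compounds named here.

Measured so far:
compound 1, `Clc1ccc(CO/N=C/c2c(-c3ccc(Br)cc3)nc3sccn23)cc1Cl`, 480 nM
compound 2, `Clc1ccc(CO/N=C/c2c(-c3ccccc3)nc3sccn23)cc1Cl`, 580 nM

In an assay on HepG2 cells for agonist activity at nuclear receptor subfamily 1 group I member 3 (Homo sapiens), read by a luciferase reporter, with a stated time of 23 h (on this read-out lower numbers stand for an effect already at smaller amounts and higher numbers for an effect only at larger amounts of compound), compound 2 stands with the highest of the two numbers, and the nearest is compound 1, whose step a 1.2-fold higher number from compound 1 to compound 2 (0.08 log units; within the scatter) lies within the scatter. Compound 3, `COc1ccc(-c2nc3sccn3c2/C=N/OCc2ccc(Cl)c(Cl)c2)cc1`, differs from compound 2 by methoxy in place of hydrogen on an aromatic carbon, a methoxy entering on an aromatic carbon. Among the compounds with values here, the one measured step that bears on this place, from compound 1 to compound 2, exchanged bromo for hydrogen there without moving the number beyond the scatter. The change to compound 3 is therefore expected to give no step beyond the scatter, a 1.2-fold lower number from compound 2 to compound 3 (0.06 log units; within the scatter). Compound 3 is estimated at 500 nM, within 200 nM to 1300 nM.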

Compound 3, half-maximal effective concentration: 490 nM
Beside the measured number, compound 3's estimate is 1.0-fold (0.01 log units) above it; the measured number falls inside the stated range.
By their numbers in this assay, from the lowest: compounds 1, 3 and 2 (each within the scatter of the next).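

In this assay methoxy in place of hydrogen gives a 1.2-fold lower number from compound 2 to compound 3 (0.07 log units; within the scatter) and methoxy in place of bromo gives a 1.0-fold higher number from compound 1 to compound 3 (0.01 log units; within the scatter) at this aromatic carbon para to a large group. Hydrogen, bromo and methoxy now all give numbers within the scatter of one another here, whereas the earlier compounds compared only hydrogen and bromo. No measurement shown explains why these numbers stay so close. Still open, as far as these compounds go, is whether an amine, a carboxylic acid or a longer chain at this place would move the number beyond the scatter.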